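The compounds below may be only part of what the source reports. "The series", "measured", "known", "first", "only" and "open" are said of these compounds alone.

Compound 1 `O=C1NC(=O)/C(=C/C(c2ccc(-c3ccc4cccc(F)c4c3)[nH]c2=O)C2CC2)O1`: in an assay on membranes from Chem-1 cells for displacement of a labelled ligand from prostaglandin E2 receptor EP3 subtype (Homo sapiens), read by scintillation counting, with a stated time of 2 h (a lower number here means a stronger inhibitor, a higher number a weaker inhibitor), compound 1 gives 22 nM.
Compound 2 `CC(C)C(c1ccc(-c2ccc3cccc(F)c3c2)[nH]c1=O)C1C(=O)NC(=O)N1C`: in this assay compound 2 gives 46 nM.

Compound 2 stands at the higher of the two numbers; compound 1 sits lower by a gap beyond the usual scatter. Compound 3 `CC(C)C(CC1NC(=O)NC1=O)c1ccc(-c2ccc3cccc(F)c3c2)[nH]c1=O` has the same atoms as compound 2, joined differently: (2,5-dioxoimidazolidin-4-yl)methyl in place of 3-methyl-2,5-dioxoimidazolidin-4-yl on a saturated chain carbon bound to an aromatic carbon and a saturated chain carbon. Among the measured compounds shown here, no measured pair shows this rearrangement, so the step from compound 2 is expected to be small, with no clear direction beyond the scatter, and is put at a 1.3-fold higher number from compound 2 to compound 3 (0.12 log units; within the scatter). For compound 3 the expected value in this assay is 60 nM, within a range of 20 nM to 180 nM.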

Compound 3, inhibition constant: 10 nM
Compound 3: the middle estimate sits 6.0-fold (0.78 log units) above what was measured; the whole stated range lies above it.
By their numbers in this assay, from the lowest: compound 3; then compound 1; then compound 2.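

In this assay, rejoining the same atoms gives a 4.6-fold lower number from compound 2 to compound 3 (0.66 log units; beyond the scatter), so the connectivity at this saturated chain carbon affects the result even with the atom count unchanged. The entering (2,5-dioxoimidazolidin-4-yl)methyl has 2 hydrogen-bond donors against 1 for the leaving 3-methyl-2,5-dioxoimidazolidin-4-yl, but no measurement links that difference to the step.

On these data alone, it remains open whether the methyl on the ring or the extra chain carbon accounts for the step. Also open, as far as these compounds go, is how a carboxylic acid would read in place of (2,5-dioxoimidazolidin-4-yl)methyl.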